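This account rests on a few compounds, and the source may have more. Where it says the series, first, only, none or still open, it means among the compounds named here.

Compound 3 `C[S+]([O-])/C=C/c1cc(=O)c2cc(F)ccc2o1` carries a fluoro group on the shared core and gives 2100 nM in a functional assay on A549 cells (Homo sapiens) for cytotoxicity, with a stated time of 48 h (a lower number here means a stronger inhibitor, a higher number a weaker inhibitor), the highest of the two numbers in hand, though its nearest neighbour compound 2 `C[S+]([O-])/C=C/c1cc(=O)c2cc(Cl)ccc2o1` gives 1700 nM and the pair differ by a 1.2-fold higher number from compound 2 to compound 3 (0.09 log units; within the scatter), within the scatter. Compound 1 `C[S+]([O-])/C=C/c1cc(=O)c2cc(C#N)ccc2o1` gives only a limit, > 10000 nM (the limit of > 10000 nM in this assay, at which 1 of the 3 values shown sits). The steps of an at least 5.8-fold lower number from compound 1 to compound 2 (0.76 log units; beyond the scatter) and an at least 4.7-fold lower number from compound 1 to compound 3 (0.67 log units; beyond the scatter) show that a change at this position can move the number, while a 1.2-fold higher number from compound 2 to compound 3 (0.09 log units; within the scatter) shows a small swap there can leave it unchanged. Compound 4 `CCCCOc1ccc2oc(/C=C/[S+](C)[O-])cc(=O)c2c1` differs from compound 3 by butoxy in place of fluoro on an aromatic carbon. Within the data shown here, no measured step covers a butoxy group, so compound 4 is expected near compound 3, with a step of a 1.2-fold lower number from compound 3 to compound 4 (0.07 log units; within the scatter) estimated, giving an estimate of 1800 nM in this assay, between 500 nM and 7000 nM.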

Compound 4, half-maximal inhibitory concentration: 1400 nM
Compound 4: middle estimate off by 1.3-fold (0.11 log units), on the high side, and the stated range covers the measured number.
By their numbers in this assay, from the lowest: compounds 4, 2 and 3 (each within the scatter of the next). At a limit, above all of these: compound 1.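

Butoxy, with 5 heavy atoms, sits at this position in place of the single fluorine of compound 3 and leaves the number within the scatter (a 1.5-fold lower number from compound 3 to compound 4 (0.18 log units; within the scatter)), and the same holds against chloro (a 1.2-fold lower number from compound 2 to compound 4 (0.08 log units; within the scatter)). So this position accepts a much larger group than a halogen, and cyano alone stands apart (an at least 7.1-fold lower number from compound 1 to compound 4 (0.85 log units; beyond the scatter)). That step is only a bound, as compound 1 gives a limit and not a number: the limit of > 10000 nM in this assay, at which 1 of the 4 values shown sits.

From the compounds shown here alone, whether an amine, a carboxylic acid or a chain longer than butoxy would keep this level at this position stays open.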